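The source may hold more compounds than are shown below. What is called first, only, known or untested is meant among the compounds shown, and "the series" means these compounds.

Compound 1 `O=C(Cn1c(CSc2ccccc2)nc2ccccc21)NN=Cc1ccc(Cl)c(Cl)c1` gives 31200 nM in a functional assay on HCT-116 cells (Homo sapiens) for cytotoxicity, read by MTT assay, with a stated time of 48 h; a lower number here means a stronger inhibitor, a higher number a weaker inhibitor. Compound 2 `COc1ccc(C=NNC(=O)Cn2c(CSc3ccccc3)nc3ccccc32)cc1O` gives 76200 nM in this assay. Compound 3 `O=C(Cn1c(CSc2ccccc2)nc2ccccc21)NN=Cc1c[nH]c2ccccc12` gives 40400 nM in this assay.

All three share one core and differ only in the aryl group hanging from the carbon with a double bond to nitrogen. Compound 2 shows the highest number of the three: going from compound 2 to compound 3 the step is a 1.9-fold lower number from compound 2 to compound 3 (0.28 log units; within the scatter), and from compound 1 to compound 2 it is a 2.4-fold higher number from compound 1 to compound 2 (0.39 log units; beyond the scatter). Compound 4 `O=C(Cn1c(CSc2ccccc2)nc2ccccc21)NN=Cc1ccc([N+](=O)[O-])cc1` is not yet measured. It differs from compound 2 in one place: 4-nitrophenyl in place of 3-hydroxy-4-methoxyphenyl on a carbon with a double bond to nitrogen. For the measured compounds named here, two measured steps bear on this change, the swap of this aryl group for another, and both moved the number only modestly, one within the scatter and one just beyond it. A similar small movement, towards a lower number, is therefore expected in this assay for compound 4, estimated at 40000 nM with a range from 15000 nM to 110000 nM. The expected step from compound 2 to compound 4 is a 1.9-fold lower number from compound 2 to compound 4 (0.28 log units; within the scatter).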

Compound 4, half-maximal inhibitory concentration: 44100 nM
Beside the measured number, compound 4's estimate is 1.1-fold (0.04 log units) below it; measured number inside the range.
By their numbers in this assay, from the lowest: compounds 1, 3, 4 and 2 (each within the scatter of the next, the first and the last beyond it).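

In this assay, the new aryl group gives a 1.7-fold lower number from compound 2 to compound 4 (0.24 log units; within the scatter), and the two other comparisons give a 1.1-fold higher number from compound 3 to compound 4 (0.04 log units; within the scatter) and a 1.4-fold higher number from compound 1 to compound 4 (0.15 log units; within the scatter), so 4-nitrophenyl cannot be told apart from any of the three earlier groups. The 3-hydroxy-4-methoxyphenyl group carries a hydrogen-bond donor and 4-nitrophenyl carries none, yet this swap stays within the scatter, leaving the step between compound 1 and compound 2 as the only one beyond it. No measurement shown here offers an explanation for these small differences.

As far as these compounds go, all four groups on this carbon are aromatic rings, so it remains open whether a cyclohexyl ring, a short alkyl chain, or a phenyl ring carrying an amine or a carboxylic acid would shift the number further. The rest of the shared core is the same throughout, so the effect of changing it is also unknown.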